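Tris-benzimidazole series: shortening the alkyl substituent to methyl

A few compounds are considered here, and "the series" means these few. Any claim that something is new, unique, unknown or untested is made for them only; others in the source may bear on it.

The series shares a linked benzimidazole core with a terminal aryl group. Compound 1 `COc1ccc(-c2ccc3[nH]c(-c4ccc5[nH]c(-c6ccc7[nH]cnc7c6)nc5c4)nc3c2)cc1` carries a methoxyphenyl end and an unsubstituted imidazole ring; in a functional assay on RPMI 8402 cells (Homo sapiens) for cytotoxicity (a lower number here means a stronger inhibitor, a higher number a weaker inhibitor), compound 1 gives 90 nM. Compound 2 `CC(C)c1nc2cc(-c3nc4cc(-c5nc6cc(-c7ccccc7)ccc6[nH]5)ccc4[nH]3)ccc2[nH]1` carries a phenyl end and an isopropyl group; in this assay compound 2 gives 60 nM. Compound 3 `CCCc1nc2cc(-c3nc4cc(-c5nc6cc(-c7ccccc7)ccc6[nH]5)ccc4[nH]3)ccc2[nH]1` carries the same phenyl end with a propyl group; in this assay compound 3 gives 60 nM, the same number as compound 2 and within the scatter of compound 1. Going by the values given here, the only one-place step measured so far, from compound 2 to compound 3, reads no change at the digits printed from compound 2 to compound 3 (within the scatter), for propyl in place of isopropyl on an aromatic carbon.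

Compound 4 `Cc1nc2cc(-c3nc4cc(-c5nc6cc(-c7ccccc7)ccc6[nH]5)ccc4[nH]3)ccc2[nH]1` is not yet measured. Against compound 3 the change is hydrogen in place of ethyl on a saturated chain carbon bound to an aromatic carbon. The step bearing on it is the alkyl exchange from compound 2 to compound 3, which left the number unchanged; the series gives no step beyond the scatter at this position. The expected step in this assay from compound 3 to compound 4 is therefore a 1.2-fold higher number from compound 3 to compound 4 (0.07 log units; within the scatter), no change beyond the scatter in either direction. For compound 4 the estimate in this assay is 70 nM, with a range from 35 nM to 150 nM.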

Compound 4, half-maximal inhibitory concentration: 110 nM
Compound 4: middle estimate off by 1.6-fold (0.20 log units), on the low side; measured number inside the range.
By their numbers in this assay, from the lowest: compounds 2, 3, 1 and 4 (each within the scatter of the next).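

In this assay, the exchange of propyl for methyl reads a 1.8-fold higher number from compound 3 to compound 4 (0.26 log units; within the scatter), and the exchange of isopropyl for methyl reads a 1.8-fold higher number from compound 2 to compound 4 (0.26 log units; within the scatter). The earlier step only compared propyl with isopropyl, whereas these two steps take the chain at this position down to methyl, and both still lie within the scatter, so the three alkyl groups shown at this position cannot be told apart in this read-out. No supporting measurement is available to account for the numbers at this position.

On these data alone, whether a different kind of group on this aromatic carbon, such as an amine, a carboxylic acid or a longer chain such as hexyl, would give a step beyond the scatter remains open, as does the result of hydrogen in place of the alkyl group in the phenyl-ended compounds. Steps between compound 1 and the other compounds cannot be read, since compound 1 differs from them in more than one place, and the separate contributions of its methoxyphenyl end and its unsubstituted imidazole ring also remain unresolved.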